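The source may hold more compounds than are shown below. What is called first, only, known or untested is meant among the compounds shown, and "the series" means these compounds.

Measured so far:
compound 1 `Fc1ccc(-c2cn3ccnc3c(-c3ccc4ncn(C5CCCCC5)c4c3)n2)cc1`, in a functional assay on SF-539 cells (Homo sapiens) for inhibition, read by sulforhodamine B assay, with a stated time of 48 h, tested at 10 uM (on this read-out higher numbers stand for more inhibition at the one concentration tested (going by the name of the read-out) and lower numbers for less inhibition), compound 1 gives 17.3%
compound 2 `c1cn2cc(-c3ccsc3)nc(-c3ccc4ncn(C5CCCCC5)c4c3)c2n1`, in this assay compound 2 gives 6.29%

Compound 2 stands lowest of the two numbers; its nearest neighbour is compound 1, separated by a number 11 percentage points lower from compound 1 to compound 2 (beyond the scatter). The next compound, compound 3 `CC(=O)c1ccc(-c2cn3ccnc3c(-c3ccc4ncn(C5CCCCC5)c4c3)n2)cc1`, differs from compound 2 by 4-acetylphenyl in place of thiophen-3-yl on an aromatic carbon. Among the measured compounds shown here, the one step that bears on this change is a number 11 percentage points lower from compound 1 to compound 2 (beyond the scatter), where moving from a six-membered carbon ring to thiophen-3-yl lowered the read-out by a modest amount beyond the scatter. Reversing that direction with 4-acetylphenyl is therefore expected to give a modest gain, a number 8.7 percentage points higher from compound 2 to compound 3 (within the scatter) in this assay. Compound 3 is estimated at 15%, within 2% to 32%.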

Compound 3, a percentage reported as inhibition, at one concentration (the size of the read-out at that concentration, not a potency): 2.82%
For compound 3 the middle estimate is 12.2 percentage points above the measured one; low and high end bracket the measured number.
By their numbers in this assay, from the lowest: compounds 3 and 2 (each within the scatter of the next); then compound 1.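

In this assay there is a number 3.5 percentage points lower from compound 2 to compound 3 (within the scatter) with 4-acetylphenyl in place of thiophen-3-yl, so the larger group does not restore the read-out at this position. There is also a number 14.5 percentage points lower from compound 1 to compound 3 (beyond the scatter) with acetyl in place of fluoro, so a six-membered aromatic ring here does not by itself keep the number of compound 1; the group it carries counts. No measurement at hand explains these numbers. Open, going by these compounds, is whether an amine or a carboxylic acid in place of the acetyl would keep the read-out. Also open, on these data alone, is how a small alkyl chain would read at this position.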